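From Cyclopropylcarbonyl to (Thiophen-2-yl)sulfonyl

The source may report more compounds than this note shows. Statements on the series, on what has been measured and on what is new or still open speak of the compounds shown alone.

Of the compounds shown here, two have been tested so far. Within the data shown here, in a functional assay on A549 cells (Homo sapiens) for antiproliferative activity, read by MTT assay, with a stated time of 48 h (on this read-out higher numbers stand for weaker inhibition and lower numbers for stronger inhibition), compound 1 `COc1ccc(C(=O)Nc2ccc3ncc(-c4cnn(C)c4)cc3n2)cc1` gives 6400 nM, the only true number available. Compound 2 `Cn1cc(-c2cnc3ccnc(NC(=O)C4CC4)c3c2)cn1` gives > 50000 nM in this assay, and this is a limit of the assay, not a number.

Compound 3 `Cn1cc(-c2cnc3ccnc(NS(=O)(=O)c4cccs4)c3c2)cn1` keeps the core of compound 2 and changes a single group: (thiophen-2-yl)sulfonyl in place of cyclopropylcarbonyl on a nitrogen on an aromatic ring. Among the measured compounds shown here, no measured pair yet shows what one such change does, so any expectation remains loose. Compound 1 differs from compound 2 in both core and attached group, and compound 1 at 6400 nM offers only a rough guide to where a measurable value might lie in this assay. A moderate move towards stronger inhibition is therefore expected, and the estimated change is an at least 2.2-fold lower number from compound 2 to compound 3 (0.35 log units; beyond the scatter). Another result reported only as a limit would not be surprising. Compound 3 is estimated at 22000 nM, with an expected range from 6000 nM to 50000 nM.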

Compound 3, half-maximal inhibitory concentration: 9400 nM
The estimate for compound 3 lay 2.3-fold (0.37 log units) above the measured number; the measured number falls inside the stated range.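

Among these compounds, on a nitrogen on an aromatic ring, (thiophen-2-yl)sulfonyl in place of cyclopropylcarbonyl gives in this assay an at least 5.3-fold lower number from compound 2 to compound 3 (0.72 log units; beyond the scatter), the first step that shows what a change in one place does, and it lies beyond the scatter. Compound 2 gives > 50000 nM, which is a limit of the assay and not a number. The step therefore fixes only a minimum for the effect of this change, and its true size stays unknown because one end of it rests on a limit: the limit of > 50000 nM in this assay, at which 1 of the 3 values shown sits.

The compounds shown leave open whether the step belongs to the sulfonyl link or to the thiophene ring, since both enter together, and a thiophene-2-carbonyl or a phenylsulfonyl group at this place would be needed to tell the two apart. Compound 1 differs from compound 3 in both core and attached group, so how a 4-methoxybenzoyl group would behave on the core of compound 2, or a (thiophen-2-yl)sulfonyl group on the core of compound 1, also remains unresolved.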